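From furan-2-yl to phenyl on a shared core

The source may report more compounds than this note shows. Statements on the series, on what has been measured and on what is new or still open speak of the compounds shown alone.

- compound 1 `CN(C)c1ncnc2c1c(-c1ccoc1)cn2[C@@H]1O[C@H](CO)[C@@H](O)[C@H]1O`: 1160 nM
- compound 2 `COc1nc(N)nc2c1c(-c1ccsc1)cn2[C@@H]1O[C@H](CO)[C@@H](O)[C@H]1O`: > 20000 nM (a limit)
- compound 3 `Nc1nc2c(c(-c3ccco3)cn2[C@@H]2O[C@H](CO)[C@@H](O)[C@H]2O)c(=O)[nH]1`: > 20000 nM (a limit)

In a functional assay on HL-60 cells (Homo sapiens) for antiproliferative activity, read by XTT assay, with a stated time of 72 h (on this read-out higher numbers stand for weaker inhibition and lower numbers for stronger inhibition), only compound 1 gives a true number, 1160 nM. Compound 2 gives > 20000 nM, which is a limit and not a number. Compound 3 gives > 20000 nM, which is likewise a limit, so its real position on the scale is not known. The set is thus dominated by the limit of > 20000 nM in this assay, at which 2 of the 3 values shown sit.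

Compound 4 `Nc1nc2c(c(-c3ccccc3)cn2[C@@H]2O[C@H](CO)[C@@H](O)[C@H]2O)c(=O)[nH]1` keeps the core of compound 3 and carries phenyl in place of furan-2-yl on an aromatic carbon. Among the compounds with values here, no measured pair in the set isolates a change of this kind, so the expectation rests on little. The expected a number no higher from compound 3 to compound 4 (the limit leaves the size open) is small, with no direction beyond the scatter foreseen in this assay. A further limit is the most likely report. The estimate for compound 4 is 20000 nM, with an expected range from 6000 nM to 40000 nM.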

Compound 4, half-maximal inhibitory concentration: > 20000 nM
Compound 4 ended at the assay's limit (the forecaster's own chance of this, stated with the estimate: 80%); the middle value sits exactly at the limit.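

Compound 3 and compound 4 both end at a limit in this assay, so no step can be read between them: the limit of > 20000 nM in this assay, at which 3 of the 4 values shown sit.

The compounds shown leave open whether phenyl and furan-2-yl differ at all on this aromatic carbon, and where compound 3 and compound 4 truly lie.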